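The source may report more compounds than this note shows. Statements on the series, on what has been measured and on what is new or still open speak of the compounds shown alone.

Measured so far in a functional assay on A549 cells (Homo sapiens) for cytotoxicity; a higher number here means that more compound is needed for the effect, a lower number that less compound is needed:

compound 1, `CCC(C)CN1CC=C(CCC/C(C)=C/C=C/[C@@H](C)CC/C=C(/C)C[C@@H]2OC(=O)C(C)=C2O)C1=O` — compound 1 gives 19 ug/mL
compound 2, `CCC(C)CN1CC=C(CCC/C(C)=C/C=C/[C@@H](C)CC/C=C(/C)C[C@H]2OC(=O)C(C)=C2O)C1=O` — compound 2 gives 27.1 ug/mL

Among the compounds with values here, compound 1 sits at the lower end of the two numbers, but the only measured step, a 1.4-fold higher number from compound 1 to compound 2 (0.15 log units; within the scatter), does not separate the pair. That step concerns only a stereocentre, as the fact that one of compounds 1 and 2 is drawn with a defined configuration and the other without, at the place where they differ records, and leaves the rest of the shared core untouched.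

Compound 3, `COC1C=C(CCC/C(C)=C/C=C/[C@@H](C)CC/C=C(/C)C[C@@H]2OC(=O)C(C)=C2O)C(=O)O1`, is not yet measured in this assay. It differs from compound 1 by a group of 8 heavy atoms (5 carbon, 3 oxygen; one five-membered non-aromatic ring with 1 hetero atom) in place of a group of 11 heavy atoms (9 carbon, 1 nitrogen, 1 oxygen; one five-membered non-aromatic ring with 1 hetero atom), on a saturated chain carbon, three bonds along the chain from a double-bonded chain carbon. Within the data shown here, no measured step in this set touches such an exchange of ring groups; the one measured step concerns a stereocentre only and gives no guidance on the size or direction of the change from compound 1 to compound 3. The expectation therefore rests on the value of compound 1 alone, with no step beyond the scatter in either direction, and with a wide range to reflect the absence of a precedent.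

In this assay compound 3 is expected to give about 20 ug/mL, within roughly 5 ug/mL to 80 ug/mL. The step implied by this estimate is a 1.1-fold higher number from compound 1 to compound 3 (0.02 log units; within the scatter).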

Compound 3, concentration for half-maximal effect: 24.1 ug/mL
Compound 3: the middle estimate sits 1.2-fold (0.08 log units) below what was measured, and the stated range covers the measured number.
By their numbers in this assay, from the lowest: compounds 1, 3 and 2 (each within the scatter of the next).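

Within the data shown here, the exchange at the saturated chain carbon, three bonds along the chain from a double-bonded chain carbon, gives the first reading in this assay of a change beyond a stereocentre, and it is a 1.3-fold higher number from compound 1 to compound 3 (0.10 log units; within the scatter). The group of 11 heavy atoms, with its nitrogen and 1 hydrogen-bond acceptor, can therefore give way to the group of 8 heavy atoms, with 3 oxygens and 3 hydrogen-bond acceptors, without a step beyond the scatter, so neither the nitrogen nor the additional carbons of the leaving group are shown to be needed for the number seen with compound 1. The information on hand concerns only how the stereocentre is drawn in the earlier pair and offers no explanation for the outcome of this exchange at this position.

As far as these compounds go, whether the position also accepts something other than a five-membered ring group, such as an open-chain amine, a carboxylic acid or a longer chain, remains open. Also open, from the compounds shown here alone, is whether the ring group of compound 3, combined with the stereocentre as drawn in compound 2, would stay within the scatter of compound 3.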